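The compounds below may be only part of what the source reports. "The series", "measured", "known", "first", "only" and "open" are said of these compounds alone.

Measured in an ADME assay on HepG2 2.2.15 cells (Homo sapiens) for cytotoxicity, read by neutral red uptake, with a stated time of 24 h; on this read-out lower numbers stand for stronger inhibition and higher numbers for weaker inhibition:

compound 1 `Nc1ncnc2c1c(F)cn2[C@@H]1C=C(CO)[C@@H](O)[C@H]1O`: > 300000 nM (a limit)
compound 2 `Nc1ncnc2c1c(Br)cn2[C@@H]1C=C(CO)[C@@H](O)[C@H]1O`: > 300000 nM (a limit)
compound 3 `C=Cc1cn([C@@H]2C=C(CO)[C@@H](O)[C@H]2O)c2ncnc(N)c12`: > 300000 nM (a limit)

Compound 3 has no numerical value on this read-out, only the limit > 300000 nM. Going by the values given here, the other two compounds give no number either, and the series so far comes down to the limit of > 300000 nM in this assay, at which 3 of the 3 values shown sit. That leaves compound 3 with no rank of its own among the three.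

The next compound, compound 4 `N#Cc1cn([C@@H]2C=C(CO)[C@@H](O)[C@H]2O)c2ncnc(N)c12`, keeps the shared core and changes one group, with cyano in place of vinyl on an aromatic carbon.

Among the compounds with values here, three measured steps bear on this change, each an exchange of one group on an aromatic carbon: a step that the two limits leave unreadable from compound 1 to compound 2, a step that the two limits leave unreadable from compound 1 to compound 3 and a step that the two limits leave unreadable from compound 2 to compound 3. None of them has a readable size, so they set no measured scale for the new exchange. They show only that fluoro, bromo and vinyl all end at the same limit in this assay. No shift in either direction can be drawn from them, and none beyond the scatter is expected.

The expected step is a number no higher from compound 3 to compound 4 (the limit leaves the size open). For compound 4 the estimated value is 300000 nM. The expected range for compound 4 runs from 120000 nM to 600000 nM, and a reading reported only as a limit is the likeliest outcome.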

Compound 4, half-maximal inhibitory concentration: > 300000 nM
Compound 4 gave a limit, no number (the forecaster's own chance of this, stated with the estimate: 85%); the middle value lies on the limit itself.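

In this assay, going by these compounds alone, compound 4 gives only a limit, like compound 1, compound 2 and compound 3, so no step between compound 4 and any of these three can be read. The compounds shown leave open whether fluoro, bromo, vinyl and cyano differ at all on this read-out, and where each compound's true value lies beyond the limit.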